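This account rests on a few compounds, and the source may have more. Where it says the series, first, only, none or still open, it means among the compounds named here.

Compound 1 `O=C(CN(C(=O)c1ccc(-c2ccccn2)cc1)C1CCCCC1)Nc1cc(F)cc(F)c1` gives 3.7
Compound 2 `O=C(CN(CC1CC1)C(=O)c1ccc(-c2ccccn2)cc1)Nc1cc(F)cc(F)c1` gives 3.1
Compound 3 `COCC(C)N(CC(=O)Nc1cc(F)cc(F)c1)C(=O)c1ccc(-c2ccccn2)cc1` gives 3

In a physicochemical assay for lipophilicity (a lower number here means a more polar compound, a higher number a more lipophilic compound), compound 3 stands at 3 and cannot be separated from compound 2, with a number 0.10 log units lower from compound 2 to compound 3 (within the scatter) as the step. Only compound 1 lies clearly apart, with a number 0.70 log units lower from compound 1 to compound 3 (beyond the scatter) as the step. Compound 4 `O=C(CN(C(=O)c1ccc(-c2ccccn2)cc1)C1CCOC1)Nc1cc(F)cc(F)c1` is still unmeasured and differs from compound 3 by oxolan-3-yl in place of 1-(methoxymethyl)ethyl on an amide-type nitrogen in one place: oxolan-3-yl in place of 1-(methoxymethyl)ethyl on an amide-type nitrogen. Within the data shown here, no measured step makes this exact change. The modest steps, a number 0.60 log units lower from compound 1 to compound 2 (beyond the scatter) and a number 0.70 log units lower from compound 1 to compound 3 (beyond the scatter), both start from cyclohexyl. The closer guide is compound 3 with a number 0.10 log units lower from compound 2 to compound 3 (within the scatter) as its step from a group other than cyclohexyl. In this assay the expected step is a number 0.20 log units lower from compound 3 to compound 4 (within the scatter) and should stay within the scatter. Compound 4 is estimated at 2.8 with an expected range from 2.4 to 3.2.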

Compound 4, distribution coefficient: 2.5
The estimate for compound 4 lay 0.30 log units above the measured number; the measured number falls inside the stated range.
By their numbers in this assay, from the lowest: compound 4; then compounds 3 and 2 (each within the scatter of the next); then compound 1.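

On the amide-type nitrogen, oxolan-3-yl and 1-(methoxymethyl)ethyl have the same heavy atoms and hydrogen-bond acceptor count, yet the ring form gave a clear change in this assay, with a number 0.50 log units lower from compound 3 to compound 4 (beyond the scatter). The two earlier replacements of cyclohexyl could not be separated, whereas oxolan-3-yl stands apart from cyclopropylmethyl, with a number 0.60 log units lower from compound 2 to compound 4 (beyond the scatter), and gives the largest change from cyclohexyl, with a number 1.20 log units lower from compound 1 to compound 4 (beyond the scatter). Nothing available explains this change. The compounds shown leave open whether the ring alone or the ring with its oxygen goes with the step, and how cyclopentyl or the ring amine pyrrolidin-3-yl would read on this nitrogen.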